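Swapping the aryl amide in a weak cytotoxic series

This account rests on a few compounds, and the source may have more. Where it says the series, first, only, none or still open, it means among the compounds named here.

Measured compounds:
compound 1, `Cc1ccc(F)cc1NC(=O)CN1CCN(c2nnc(Cc3ccccc3)c3ccccc23)CC1`, "not active" (no number reported)
compound 2, `Cc1ccccc1NC(=O)CN1CCN(c2nnc(Cc3ccncc3)c3ccccc23)CC1`, 43100 nM
compound 3, `Cc1ccc(F)cc1NC(=O)CN1CCN(c2nnc(Cc3ccncc3)c3ccccc23)CC1`, 38900 nM

All three were tested in a functional assay on A549 cells (Homo sapiens) for cytotoxicity, read by MTT assay, with a stated time of 72 h; a lower number here means a stronger inhibitor, a higher number a weaker inhibitor. Compound 1 gives "not active" (no number reported), so no number stands for it and it can only be placed as weaker than anything with a reported value. Compound 2 gives 43100 nM and compound 3 gives 38900 nM; both are weak. Among the compounds with values here, the only one-change step among them, a 1.1-fold lower number from compound 2 to compound 3 (0.04 log units; within the scatter), shows that adding a fluoro to the aryl on the amide nitrogen leaves the read-out essentially unchanged.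

The new compound is compound 4, `Cc1cccc(Cl)c1NC(=O)CN1CCN(c2nnc(Cc3ccccc3)c3ccccc23)CC1`. Relative to compound 1 it carries 2-chloro-6-methylphenyl in place of 5-fluoro-2-methylphenyl on an amide-type nitrogen. Within the data shown here, the rest of the molecule stays as in compound 1, which differs from compounds 2 and 3 elsewhere, so no measured step matches this change directly. The step from compound 2 to compound 3 is the nearest guide, and it suggests that small changes on this aryl ring do little. Since compound 1 showed "not active" (no number reported), compound 4 is expected to stay weak, with a fair chance of again returning no number. The estimate for compound 4 is 60000 nM, in the range 20000 nM to 200000 nM.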

Compound 4, half-maximal inhibitory concentration: 7420 nM
Beside the measured number, compound 4's estimate is 8.1-fold (0.91 log units) above it; measured number outside the range, below it.
By their numbers in this assay, from the lowest: compound 4; then compounds 3 and 2 (each within the scatter of the next).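

Within the data shown here, compound 1 gives "not active" (no number reported) and compound 4 gives 7420 nM, so no step from compound 1 to compound 4 can be read. No measurement shown offers an explanation for the value of compound 4. The compounds shown leave open how much 2-chloro-6-methylphenyl in place of 5-fluoro-2-methylphenyl on the amide-type nitrogen changes the read-out.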